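This account rests on a few compounds, and the source may have more. Where it says the series, first, only, none or still open, it means among the compounds named here.

Compound 1 `C/C(=N\NC(=O)c1cccc(S(=O)(=O)N2CCOCC2)c1)c1cccc(N)c1` and compound 2 `C/C(=N\NC(=O)c1cccc(S(=O)(=O)N2CCOCC2)c1)c1ccc(F)cc1` share one core and differ only in the ring attached to the carbon with a double bond to nitrogen. In a functional assay on EC9706 cells (Homo sapiens) for antiproliferative activity, read by MTT assay, with a stated time of 72 h (a lower number here means a stronger inhibitor, a higher number a weaker inhibitor), compound 1 gives > 100000 nM, which is a limit of the assay rather than a number. In this assay compound 2 gives > 100000 nM, again only a limit. The step that the two limits leave unreadable from compound 1 to compound 2 is therefore unreadable, as the limit of > 100000 nM in this assay, at which 2 of the 2 values shown sit, shows. Compound 3 `C/C(=N\NC(=O)c1cccc(S(=O)(=O)N2CCOCC2)c1)c1ccccc1O` differs from compound 2 by 2-hydroxyphenyl in place of 4-fluorophenyl on a carbon with a double bond to nitrogen. No measured step sizes such a change, so no shift beyond the scatter can be foreseen. For compound 3 the estimated value is 150000 nM, expected between 40000 nM and 600000 nM. The expected step is a step that the limit leaves unreadable from compound 2 to compound 3.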

Compound 3, half-maximal inhibitory concentration: 1220 nM
Compound 3: the middle estimate sits 120-fold (2.09 log units) above what was measured; the measured number lies below the stated range.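

In this assay, 2-hydroxyphenyl on the carbon with a double bond to nitrogen brings activity into a readable range, giving an at least 81-fold lower number from compound 2 to compound 3 (1.91 log units; beyond the scatter) and an at least 81-fold lower number from compound 1 to compound 3 (1.91 log units; beyond the scatter). The two earlier compounds could not show that the ring at this place can matter so much. Unlike 4-fluorophenyl, the entering group counts a hydrogen-bond donor and a hydrogen-bond acceptor, but this comparison does not show that either one is responsible.

As far as these compounds go, the full size of both steps stays open, because compound 1 and compound 2 are known only by a limit: the limit of > 100000 nM in this assay, at which 2 of the 3 values shown sit. From the compounds shown here alone, whether a methoxy group in place of the hydroxyl would keep this activity also remains open.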